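A few compounds are considered here, and "the series" means these few. Any claim that something is new, unique, unknown or untested is made for them only; others in the source may bear on it.

Compound 1 `Cn1c(-c2ccc([S+](C)[O-])cc2)nc2c(Sc3ccccc3)ncnc21` is the starting point. In an assay on isolated protein for inhibition of Ca2+/calmodulin-dependent protein kinase II (CaM kinase II) (Rattus norvegicus), tested at 30 uM (a higher number here means more inhibition at the concentration tested (going by the name of the read-out), a lower number less inhibition), compound 1 gives 8%. Compound 2 `Cn1c(-c2ccc([S+](C)[O-])cc2)nc2c(Sc3ccc(F)cc3)ncnc21` differs from it by fluoro in place of hydrogen on an aromatic carbon; in this assay compound 2 gives 12%, a step of a number 4 percentage points higher from compound 1 to compound 2 (within the scatter). Compound 3 `Cn1c(-c2ccc(S(C)(=O)=O)cc2)nc2c(Sc3ccccc3)ncnc21` differs from compound 1 by a group of 4 heavy atoms (1 carbon, 2 oxygen, 1 sulfur; no ring) in place of a group of 3 heavy atoms (1 carbon, 1 oxygen, 1 sulfur; no ring), on an aromatic carbon; in this assay compound 3 gives 8%, a step of no change at the digits printed from compound 1 to compound 3 (within the scatter). Compound 4 `Cn1c(-c2ccc(S(C)(=O)=O)cc2)nc2c(Sc3ccc(F)cc3)ncnc21` has not been measured. It differs from compound 3 by fluoro in place of hydrogen on an aromatic carbon, the same change as from compound 1 to compound 2, at the same place. The step is expected to be a number 4 percentage points higher from compound 3 to compound 4 (within the scatter), resting on the earlier step of a number 4 percentage points higher from compound 1 to compound 2 (within the scatter), since both parent compounds share the same low level. Compound 4 is therefore estimated to give 12% in this assay, with a range from 0% to 26%.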

Compound 4, a percentage reported as inhibition, at one concentration (the size of the read-out at that concentration, not a potency): 0%
For compound 4 the middle estimate is 12 percentage points above the measured one; low and high end bracket the measured number.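

In this assay, putting fluoro in place of hydrogen gives a number 8 percentage points lower from compound 3 to compound 4 (within the scatter), and beside the earlier step this shows no real difference between the two cores: the same change on two cores in this assay, a number 4 percentage points higher (within the scatter) from compound 1 to compound 2 and a number 8 percentage points lower (within the scatter) from compound 3 to compound 4, 12 percentage points apart, within the scatter of two such steps. Exchanging the sulfur-bearing group on the fluorinated compounds gives a number 12 percentage points lower from compound 2 to compound 4 (beyond the scatter), and this too agrees with its counterpart on the unfluorinated core: the same change on two cores in this assay, no change at the digits printed (within the scatter) from compound 1 to compound 3 and a number 12 percentage points lower (beyond the scatter) from compound 2 to compound 4, 12 percentage points apart, within the scatter of two such steps. Both changes are therefore consistent with carrying over from one core to the other, but with so few low readings at one concentration, this does not show that either has a reproducible effect that transfers.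

Still open, going by these compounds, is whether an amine or a carboxylic acid in place of the fluoro would change the inhibition. A longer chain on the sulfur also remains untested in the compounds shown.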